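Halogen swap on the aryl ether of the spiro series

This account rests on a few compounds, and the source may have more. Where it says the series, first, only, none or still open, it means among the compounds named here.

Going by the values given here, compound 2 `NC1=NC2(CCOCC2)N(OCCCOc2cccc(Cl)c2Cl)C(N)=N1` stands at the higher of the two values so far: in a functional assay on A549 cells (Homo sapiens) for antiproliferative activity, read by MTT assay, with a stated time of 72 h (a lower number here means a stronger inhibitor, a higher number a weaker inhibitor), compound 2 gives 100 nM, whereas compound 1 `CC(C)(C)c1ccc(OCCCON2C(N)=NC(N)=NC23CCSCC3)cc1` gives 1 nM, a gap well beyond the scatter. The next analogue, compound 3 `NC1=NC2(CCOCC2)N(OCCCOc2cccc(Br)c2)C(N)=N1`, differs from compound 2 only in the aryl group: 3-bromophenyl in place of 2,3-dichlorophenyl on an oxygen on a saturated carbon. Among the compounds with values here, no measured step of this kind exists, so the size and direction of the change are uncertain; a shift of modest size, likely within or just beyond the scatter, is expected from compound 2 to compound 3, a 1.5-fold higher number from compound 2 to compound 3 (0.18 log units; within the scatter). Compound 3 is therefore estimated at 150 nM, with a range of 40 nM to 600 nM.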

Compound 3, half-maximal inhibitory concentration: 160 nM
Compound 3: the middle estimate sits 1.1-fold (0.03 log units) below what was measured; low and high end bracket the measured number.
By their numbers in this assay, from the lowest: compound 1; then compounds 2 and 3 (each within the scatter of the next).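

In this assay, the exchange on the aryl ether gives a 1.6-fold higher number from compound 2 to compound 3 (0.20 log units; within the scatter). At this position, on an oxygen on a saturated carbon, 3-bromophenyl and 2,3-dichlorophenyl are therefore not told apart, although the halogen and the number of halogen atoms both differ. Nothing measured here bears on the reason for this result.

As far as these compounds go, because both features change at once, their separate contributions remain open, and a 3-chlorophenyl analogue would address this. Also open, from the compounds shown here alone, is whether an amine or a carboxylic acid on the phenyl ring would leave the number equally unchanged.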